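Ethyl at the quinoline-free core: expected cytotoxicity of compound 4

The compounds below may be only part of what the source reports. "The series", "measured", "known", "first", "only" and "open" are said of these compounds alone.

Measured compounds:
- Compound 1, `CCCCCc1cc2ccccc2nc1-c1cn(CCC(F)(F)C(F)(F)C(F)(F)C(F)(F)C(F)(F)C(F)(F)C(F)(F)C(F)(F)F)nn1`. In a functional assay on HeLa cells (Homo sapiens) for cytotoxicity, read by MTT assay, with a stated time of 24 h (a higher number here means a weaker inhibitor, a lower number a stronger inhibitor), compound 1 gives > 100 ug/mL, which is a limit of the assay rather than a number.
- Compound 2, `CCCCCc1cc2ccccc2nc1-c1cn(-c2ccc(F)cc2)nn1`. In this assay compound 2 gives > 100 ug/mL, again a limit.
- Compound 3, `CCc1cc2ccccc2nc1-c1cn(CCC(F)(F)C(F)(F)C(F)(F)C(F)(F)C(F)(F)C(F)(F)C(F)(F)C(F)(F)F)nn1`. In this assay compound 3 gives > 100 ug/mL, also a limit.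

Compound 3 therefore stands where every other measured compound stands: at the limit of > 100 ug/mL in this assay, at which 3 of the 3 values shown sit. Within the data shown here, no compound shows a number below that limit, so none can be called stronger or weaker than another. Among the measured compounds shown here, the one single-point change among the measured compounds, a step that the two limits leave unreadable from compound 1 to compound 3, is unreadable for the same reason, because both ends of it are limits.

Compound 4 is `CCCCc1cc2ccccc2nc1-c1cn(CCC(F)(F)C(F)(F)C(F)(F)C(F)(F)C(F)(F)C(F)(F)C(F)(F)C(F)(F)F)nn1`. Relative to compound 3 the change is ethyl in place of hydrogen on a saturated chain carbon, two bonds along the chain from an aromatic carbon. For the measured compounds named here, the only comparable measured step, the one from compound 1 to compound 3, gives no size in either direction, so there is no basis for expecting any readable step in this assay here.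

For compound 4 the expected step that the limit leaves unreadable from compound 3 to compound 4 is none beyond the scatter. Compound 4 is therefore estimated at 150 ug/mL, within 50 ug/mL to 500 ug/mL, most likely reported again only as a limit.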

Compound 4, half-maximal inhibitory concentration: 32.8 ug/mL
Beside the measured number, compound 4's estimate is 4.6-fold (0.66 log units) above it, outside the stated range (below it).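

In this assay, extending the ethyl of compound 3 to a butyl gives an at least 3.0-fold lower number from compound 3 to compound 4 (0.48 log units; beyond the scatter), the first sign that cytotoxicity responds to a change at this position on the saturated chain. Shortening the longer chain of compound 1 to that same butyl gives an at least 3.0-fold lower number from compound 1 to compound 4 (0.48 log units; beyond the scatter), so compound 4 has a lower number than both the shorter-chain and the longer-chain compound, and among these three the effect does not simply grow with chain length. Compound 4 is also the only compound shown that gives a number rather than a limit: the limit of > 100 ug/mL in this assay, at which 3 of the 4 values shown sit.

The step between the two chains at the limit, compound 1 and compound 3, still cannot be read, and three compounds cannot show whether butyl is a true optimum, or whether a propyl chain, a branched chain or a chain ending in an amine would give a lower number still. Going by these compounds, it also remains open whether the butyl chain would keep its effect if the long fluorinated chain of compound 4 were replaced by the fluorophenyl group of compound 2.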